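Trading a Ring-Bearing Amine for a Short Open Chain

The source may report more compounds than this note shows. Statements on the series, on what has been measured and on what is new or still open speak of the compounds shown alone.

Compound 1 `O[C@@H]1Cc2ccccc2[C@H]1NC1CCN(CCCc2c[nH]c3ccc(-n4cnnc4)cc23)CC1` gives 6.6 nM in an assay on CHO cells for displacement of a labelled ligand from 5-hydroxytryptamine receptor 1D (Homo sapiens); on this read-out higher numbers stand for weaker inhibition and lower numbers for stronger inhibition. Among the three compounds measured, compound 1 has the highest number: compound 3 `C[C@@H](NC1CCN(CCCc2c[nH]c3ccc(-n4ccnc4)cc23)CC1)c1ccccc1` gives 4.2 nM, within the scatter of compound 1, while compound 2 `CC(=O)Nc1ccc([C@H](C)NCC2CCN(CCCc3c[nH]c4ccc(-n5cnnc5)cc34)CC2)cc1` gives 0.6 nM, a gap beyond the scatter. The next compound, compound 4 `CC(C)=CCN(C)C1CCN(CCCc2c[nH]c3ccc(-n4cnnc4)cc23)CC1`, differs from compound 1 in one place: methyl(3-methylbut-2-en-1-yl)amino in place of (2-hydroxy-2,3-dihydro-1H-inden-1-yl)amino on a saturated ring carbon. Within the data shown here, no measured pair shows this kind of change, so its size is unknown. The entering group is smaller, has no ring and no hydrogen-bond donor; the expected step from compound 1 to compound 4 is a 4.5-fold higher number from compound 1 to compound 4 (0.66 log units; beyond the scatter), towards weaker binding, beyond the scatter. Compound 4 is expected to give 30 nM, in a range from 8 nM to 120 nM.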

Compound 4, half-maximal inhibitory concentration: 0.5 nM
Compound 4: middle estimate off by 60-fold (1.78 log units), on the high side; the whole stated range lies above it.
By their numbers in this assay, from the lowest: compounds 4 and 2 (each within the scatter of the next); then compounds 3 and 1 (each within the scatter of the next).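

On the saturated ring carbon, methyl(3-methylbut-2-en-1-yl)amino in place of (2-hydroxy-2,3-dihydro-1H-inden-1-yl)amino gives a 13-fold lower number from compound 1 to compound 4 (1.12 log units; beyond the scatter) in this assay. A low number at this position therefore needs neither a ring nor a hydrogen-bond donor in this group, as a smaller open chain with neither suffices. Nothing available explains the size of this step. The compounds shown leave open whether the double bond, the methyl on nitrogen or the loss of the ring matters most. A saturated 3-methylbutyl chain or a plain dimethylamino group here would help separate these.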